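Swapping acetamido for azidomethyl on a fused aromatic core

A few compounds are considered here, and "the series" means these few. Any claim that something is new, unique, unknown or untested is made for them only; others in the source may bear on it.

Measured so far in a toxicity assay on CCRF-CEM cells (Homo sapiens) for cytotoxicity; on this read-out lower numbers stand for higher toxicity in this test and higher numbers for lower toxicity in this test:
Compound 1 `Nc1cccc2c1nc(-c1c(F)cccc1F)n2Cc1c(F)cccc1F`: compound 1 gives 26.3 uM
Compound 2 `CC(=O)Nc1cccc2c1nc(-c1c(F)cccc1F)n2Cc1c(F)cccc1F`: compound 2 gives 39.3 uM

Compound 2 has the highest of the two numbers, meaning the lowest toxicity seen so far, but its nearest neighbour is compound 1, and the step of a 1.5-fold higher number from compound 1 to compound 2 (0.17 log units; within the scatter) is within the scatter, so the two compounds cannot be told apart on this read-out.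

Compound 3 `[N-]=[N+]=NCc1cccc2c1nc(-c1c(F)cccc1F)n2Cc1c(F)cccc1F` differs from compound 2 in one place: azidomethyl in place of acetamido on an aromatic carbon. For the measured compounds named here, the only measured step that touches the same position, the one from compound 1 to compound 2, exchanged a hydrogen for an acetyl on the ring nitrogen and moved the number by no more than the scatter. Going by the values given here, no measured step replaces a nitrogen-linked group with a carbon-linked azide, so there is nothing to suggest a large move in either direction in this assay. The expected step is therefore a 1.3-fold lower number from compound 2 to compound 3 (0.12 log units; within the scatter), lying within the scatter. Compound 3 is estimated at 30 uM, with a range from 12 uM to 75 uM.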

Compound 3, half-maximal toxic concentration: > 100 uM
Compound 3: no number, only a limit; the forecaster's own chance of this, stated with the estimate: 5%; middle value at least 3.3-fold (0.52 log units) away from the limit.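

Azidomethyl on this aromatic carbon separates from both earlier groups in this assay: in place of acetamido it gives an at least 2.5-fold higher number from compound 2 to compound 3 (0.40 log units; beyond the scatter), and in place of amino it gives an at least 3.8-fold higher number from compound 1 to compound 3 (0.58 log units; beyond the scatter). Both steps lie beyond the scatter, whereas the earlier change at this place, a 1.5-fold higher number from compound 1 to compound 2 (0.17 log units; within the scatter), stayed within it, so the group on this carbon can move the read-out towards lower toxicity in this test, which compounds 1 and 2 alone did not show. Compound 3 gives > 100 uM, which is a limit of the assay and not a number.

How large the two steps really are stays open, because the reading for compound 3 is a limit: the limit of > 100 uM in this assay, at which 1 of the 3 values shown sits.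

Going by these compounds, it also stays open whether the azide itself or the carbon link to the ring goes with the higher number, a question that an aminomethyl group or a plain methyl on the same aromatic carbon would help to settle.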